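Swapping the Benzothiazole Attachment on a Shared Core

The source may report more compounds than this note shows. Statements on the series, on what has been measured and on what is new or still open speak of the compounds shown alone.

Measured so far in a functional assay (blood) for inhibition, with Homo sapiens as the target; on this read-out higher numbers stand for weaker inhibition and lower numbers for stronger inhibition:
Compound 1 `CC(C)(C)Sc1c(CC(C)(C)C(=O)O)n(Cc2ccc(Cl)cc2)c2ccc(OCc3ccc4cc(F)c(F)cc4n3)cc12` gives > 3000 nM (a limit of the assay).
Compound 2 `CC(C)(C)Sc1c(CC(C)(C)C(=O)O)n(Cc2ccc(Cl)cc2)c2ccc(OCc3nc4ccccc4s3)cc12` gives 260 nM.

Among the measured compounds shown here, compound 2 is the only compound here with a true number, so it is the sole firm reference point. The next compound, compound 3 `Cc1nc2ccc(COc3ccc4c(c3)c(SC(C)(C)C)c(CC(C)(C)C(=O)O)n4Cc3ccc(Cl)cc3)cc2s1`, keeps the shared core and changes one group on a saturated chain carbon bound to an oxygen on an aromatic ring: 2-methyl-1,3-benzothiazol-6-yl in place of 1,3-benzothiazol-2-yl on a saturated chain carbon bound to an oxygen on an aromatic ring. In words, 2-methyl-1,3-benzothiazol-6-yl takes the place of 1,3-benzothiazol-2-yl.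

For the measured compounds named here, only one measured step bears on this change. The step of an at least 11-fold lower number from compound 1 to compound 2 (1.06 log units; beyond the scatter) is large and beyond the scatter, and it involves a swap at this same place. It shows that the group here can matter greatly, although it tests a different exchange. The data contain no direct test of the new group, so the forecast is uncertain, and a moderate loss of inhibition seems more likely than a gain. The expected step is a 1.9-fold higher number from compound 2 to compound 3 (0.28 log units; within the scatter). For compound 3 the estimated value is 500 nM, with an expected range from 120 nM to 2000 nM.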

Compound 3, half-maximal inhibitory concentration: > 3000 nM
Compound 3 ended at the assay's limit (the forecaster's own chance of this, stated with the estimate: 15%); middle value at least 6.0-fold (0.77 log units) away from the limit.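

In this assay, moving from 1,3-benzothiazol-2-yl to 2-methyl-1,3-benzothiazol-6-yl on the saturated chain carbon gives an at least 11-fold higher number from compound 2 to compound 3 (1.06 log units; beyond the scatter). The earlier step showed that this place matters when one ring system replaces a different one, whereas this result shows that a benzothiazole here does not by itself keep the inhibition of compound 2: the two groups have the same ring types and the same counts of hydrogen-bond donors and acceptors, yet their values lie far apart. Compound 3 gives > 3000 nM, which is a limit and not a number, so the full size of the loss stays unknown, and the limit is shared within this small set: the limit of > 3000 nM in this assay, at which 2 of the 3 values shown sit.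

The step from compound 1 to compound 3 cannot be read, as both values are limits, so those two groups cannot be ranked against each other. The change from compound 2 to compound 3 alters both the added methyl and the point of attachment, so the compounds shown cannot separate the two, and a plain 1,3-benzothiazol-6-yl group would be the missing link.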